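The source may hold more compounds than are shown below. What is called first, only, known or untested is meant among the compounds shown, and "the series" means these compounds.

Three compounds were examined for their effect on skin cells. Compound 1 `C=C1C(=O)O[C@H](C2=C(C)C(OC)CC2=O)[C@@H]1[C@@H](O)CC(C)=O` gives 1% in a functional assay on HaCaT cells (Homo sapiens) for cytotoxicity, read by ELISA and LDH release, with a stated time of 6 h, tested at 75 ug/mL; on this read-out higher numbers stand for a weaker effect at the one concentration tested and lower numbers for a stronger effect. Compound 2 `C=C1C(=O)O[C@H](C2=C(C)C(O)CC2=O)[C@@H]1CCC(C)=O` gives 0% in this assay, and compound 3 `C=C1C(=O)O[C@H](C2=C(C)[C@@H](OC)CC2=O)[C@@H]1CCC(C)=O` gives 0% in this assay, level with compound 2 at the digits shown and within the scatter of compound 1; all three numbers stand at the strong end of the read-out. Compound 4 `C=C1C(=O)O[C@H](C2=C(C)[C@@H](O)CC2=O)[C@@H]1CCC(C)=O` differs from compound 3 by hydrogen in place of methyl on an oxygen on a saturated carbon. Within the data shown here, no step between measured compounds is available for this change. Because compound 3 gives 0% and the remaining compounds sit in the same place, the step from compound 3 to compound 4 is expected to be a number 2 percentage points higher from compound 3 to compound 4 (within the scatter), none beyond the scatter. Compound 4 is therefore estimated to give 2% in this assay, within 0% to 12%.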

Compound 4, a percentage reported as activity, at one concentration (the size of the read-out at that concentration, not a potency): 2%
Compound 4: the middle estimate sits on the measured number at the digits printed; low and high end bracket the measured number.
By their numbers in this assay, from the lowest: compounds 2, 3, 1 and 4 (each within the scatter of the next).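

In this assay, replacing methoxy with hydroxy on the saturated ring carbon gives a number 2 percentage points higher from compound 3 to compound 4 (within the scatter), so this change leaves the read-out at the strong end. The second step, a number 2 percentage points higher from compound 2 to compound 4 (within the scatter), does not compare two defined configurations at this carbon, and its reading is limited by this: the fact that one of compounds 2 and 4 is drawn with a defined configuration and the other without, at the place where they differ.

The compounds shown leave open whether an amine or a longer ether chain at this place would move the read-out, and what the opposite drawn configuration would give. On these data alone, with all the values at the strong end at one concentration, any differences that might appear at lower concentrations also remain open.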